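This account rests on a few compounds, and the source may have more. Where it says the series, first, only, none or still open, it means among the compounds named here.

Measured in a functional assay on HT-29 cells (Homo sapiens) for antiproliferative activity, read by sulforhodamine B assay, with a stated time of 48 h; on this read-out lower numbers stand for stronger inhibition and higher numbers for weaker inhibition:
- compound 1 `CCc1ccc(NS(=O)(=O)c2ccc(N3CCNC3=O)cc2)cc1`: 660 nM
- compound 2 `CCc1cccc(NS(=O)(=O)c2ccc(N3CCNC3=O)cc2)c1`: 110 nM
- compound 3 `COc1ccc(NS(=O)(=O)c2ccc(N3CCNC3=O)cc2)cc1`: 800 nM

Compound 3 and compound 1 cannot be told apart on these numbers, as the comparison between them shows: a 1.2-fold higher number from compound 1 to compound 3 (0.08 log units; within the scatter). Compound 2 stands clearly apart from compound 3, with a 7.3-fold higher number from compound 2 to compound 3 (0.86 log units; beyond the scatter).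

The next compound to be tested is compound 4 `COc1cccc(NS(=O)(=O)c2ccc(N3CCNC3=O)cc2)c1`, which keeps the shared core and moves the methoxy group: 3-methoxyphenyl in place of 4-methoxyphenyl on a sulfonamide nitrogen. In short, 3-methoxyphenyl sits in place of 4-methoxyphenyl on a sulfonamide nitrogen.

The closest guide is the same kind of shift made with an ethyl group, which gave a 6.0-fold lower number from compound 1 to compound 2 (0.78 log units; beyond the scatter). The swap of ethyl for methoxy gave a 1.2-fold higher number from compound 1 to compound 3 (0.08 log units; within the scatter), so the ethyl result seems a fair guide for the methoxy pair. Still, this shift has been measured only once, and never with methoxy, so its size may not carry over exactly.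

A step of similar size, towards stronger inhibition and beyond the scatter, is therefore expected, and the expected step is a 5.7-fold lower number from compound 3 to compound 4 (0.76 log units; beyond the scatter). In this assay, the estimate for compound 4 is 140 nM, with an expected range from 50 nM to 400 nM.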

Compound 4, half-maximal inhibitory concentration: 120 nM
Compound 4: the middle estimate sits 1.2-fold (0.07 log units) above what was measured; the range from low to high includes it.
By their numbers in this assay, from the lowest: compounds 2 and 4 (each within the scatter of the next); then compounds 1 and 3 (each within the scatter of the next).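

Moving the group from 4-methoxyphenyl to 3-methoxyphenyl on the sulfonamide nitrogen gives a 6.7-fold lower number from compound 3 to compound 4 (0.82 log units; beyond the scatter), so the shift that strengthened inhibition with ethyl now does the same with a second group, in the same direction and beyond the scatter. The identity of the group counts for little here: exchanging 4-ethylphenyl for 3-methoxyphenyl gives a 5.5-fold lower number from compound 1 to compound 4 (0.74 log units; beyond the scatter), much like the shift alone, while methoxy in place of ethyl gives a 1.1-fold higher number from compound 2 to compound 4 (0.04 log units; within the scatter), which leaves compound 2 and compound 4 indistinguishable. The swap of ethyl for methoxy thus reads the same whichever of the two arrangements carries it, so in this assay the place of the group matters far more than which of these two groups it is: the same change on two cores in this assay, a 1.2-fold higher number (0.08 log units; within the scatter) from compound 1 to compound 3 and a 1.1-fold higher number (0.04 log units; within the scatter) from compound 2 to compound 4, 1.1-fold (0.05 log units) apart, within the scatter of two such steps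

On these data alone, these compounds hold only ethyl and methoxy, so how an amine, a carboxylic acid or a longer chain such as butyl would behave on the same ring stays open. A plain phenyl on the sulfonamide nitrogen would show whether the 3-ethylphenyl and 3-methoxyphenyl compounds gain from their group or the 4-ethylphenyl and 4-methoxyphenyl compounds lose from theirs.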